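This account rests on a few compounds, and the source may have more. Where it says the series, first, only, none or still open, it means among the compounds named here.

In a functional assay on MKN-74 cells (Homo sapiens) for antiproliferative activity, with a stated time of 24 h (on this read-out lower numbers stand for stronger inhibition and higher numbers for weaker inhibition), three compounds have been measured:

Compound 1 `Cc1ccccc1CN1CCc2c(sc(NC(=O)c3ccccc3Cl)c2C(N)=O)C1`: > 50000 nM, a limit of the assay
Compound 2 `NC(=O)c1c(NC(=O)c2ccccc2Cl)sc2c1CCN(Cc1c(Cl)cccc1Cl)C2`: 4740 nM
Compound 3 `NC(=O)c1c(NC(=O)c2ccccc2Cl)sc2c1CCN(Cc1ccc(Cl)cc1Cl)C2`: 16300 nM

Among the two true numbers, compound 3 has the higher one, and the gap to its nearest neighbour is a 3.4-fold higher number from compound 2 to compound 3 (0.54 log units; beyond the scatter), a modest step. Compound 4 `Cc1ccc(C(=O)Nc2sc3c(c2C(N)=O)CCN(Cc2ccc(Cl)cc2Cl)C3)cc1` carries 4-methylphenyl in place of 2-chlorophenyl on a carbonyl carbon.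

Within the data shown here, no measured step changes this group. All three alter the aryl group on a saturated chain carbon bound to an amine nitrogen in a ring. Besides the step above, they are the large at least 10-fold lower number from compound 1 to compound 2 (1.02 log units; beyond the scatter) and the at least modest an at least 3.0-fold lower number from compound 1 to compound 3 (0.48 log units; beyond the scatter). That last step, from a methylphenyl to a chlorinated phenyl, favoured the chlorinated compound, but at another place, so it supports only a slight lean towards a higher number. The expectation therefore stays anchored on compound 3 at 16300 nM, with no shift beyond the scatter expected and a wide margin of uncertainty.

The expected change is a 1.3-fold higher number from compound 3 to compound 4 (0.13 log units; within the scatter).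

For compound 4 the estimated value is 22000 nM, with an expected range from 7000 nM to 50000 nM.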

Compound 4, half-maximal inhibitory concentration: 25500 nM
Beside the measured number, compound 4's estimate is 1.2-fold (0.06 log units) below it; the range from low to high includes it.
By their numbers in this assay, from the lowest: compound 2; then compounds 3 and 4 (each within the scatter of the next). At a limit, above all of these: compound 1.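

Unlike the earlier steps, which all altered the aryl group on the saturated chain carbon, this change acts on the carbonyl carbon whose other neighbour is the amide-type nitrogen, and in this assay it gives a 1.6-fold higher number from compound 3 to compound 4 (0.19 log units; within the scatter). So this position took 4-methylphenyl in place of 2-chlorophenyl with no shift beyond the scatter, whereas each step at the other place lay beyond it. Nothing measured here offers a reason for this outcome.

The change swaps chlorine for methyl and alters the group's substitution pattern at once, so the compounds shown do not separate the two, and whether it would read the same alongside the 2,6-dichlorophenyl group of compound 2 stays open. Also open, as far as these compounds go, is what a pyridine ring or a saturated amine would do on this carbonyl carbon.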